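This account rests on a few compounds, and the source may have more. Where it says the series, first, only, none or still open, it means among the compounds named here.

Compound 2 `COc1ccc(-c2cc(/C=C/C(=O)c3ccc(N)cc3)[nH]n2)cc1OC` and compound 1 `COc1ccc(-c2cc(/C=C/C(=O)c3ccc(N)cc3)[nH]n2)cc1` differ in one place: hydrogen in place of methoxy on an aromatic carbon. In a functional assay on NCI-H226 cells (Homo sapiens) for cytotoxicity, read by sulforhodamine B assay, with a stated time of 48 h, tested at 1 uM (a higher number here means a weaker effect of the compound at the concentration tested, a lower number a stronger effect), compound 2 gives 86%, and in this assay compound 1 gives 86%, so the step of no change at the digits printed from compound 2 to compound 1 (within the scatter). Compound 3 `COc1cc(C(=O)/C=C/c2cc(-c3cc(OC)c(OC)c(OC)c3)n[nH]2)cc(OC)c1OC` is built on a different core; how its core differs from that of compound 2 is not broken down here. In this assay compound 3 gives 86%, level with compound 1 and compound 2 within the scatter.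

Compound 4 `COc1ccc(-c2cc(/C=C/C(=O)c3cc(OC)c(OC)c(OC)c3)[nH]n2)cc1OC` has not yet been measured. It arises from compound 3 by hydrogen in place of methoxy on an aromatic carbon. Among the compounds with values here, this is the same kind of change as the one from compound 2 to compound 1, though the surroundings are not identical: in compound 3 the aromatic carbon that loses the methoxy is also meta to a methoxy group, while in compound 2 it is ortho to a methoxy group and meta to a large group. Because the earlier step of no change at the digits printed from compound 2 to compound 1 (within the scatter) left the read-out unchanged, compound 4 is expected to show a step of no change at the digits printed from compound 3 to compound 4 (within the scatter). Compound 4 is therefore estimated to give 86% in this assay, most likely between 74% and 98%.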

Compound 4, a percentage reported as activity, at one concentration (the size of the read-out at that concentration, not a potency): 73%
Compound 4: middle estimate off by 13 percentage points, on the high side; measured number below the stated range.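

In this assay, putting hydrogen in place of one methoxy group on an aromatic carbon gives a number 13 percentage points lower from compound 3 to compound 4 (beyond the scatter), while the same change on the other core gave no change at the digits printed from compound 2 to compound 1 (within the scatter). Read alone, the new step suggests that the change can matter on the core of compound 3, but set beside the earlier step it gives no firm sign that the two cores respond differently: the same change on two cores in this assay, no change at the digits printed (within the scatter) from compound 2 to compound 1 and a number 13 percentage points lower (beyond the scatter) from compound 3 to compound 4, 13 percentage points apart, within the scatter of two such steps Nor does this show that the change carries over unaltered from one core to the other, as two pairs are a thin base for such a rule and they offer no explanation for the two results.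

The compounds shown leave open how a hydroxyl group, a fluorine atom or a longer chain such as ethoxy would read at this place on the ring. Each result is also a read-out at a single concentration, which leaves open how the effects of these compounds compare at other concentrations.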